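Replacing bromo with methoxy in compound 3

The source may report more compounds than this note shows. Statements on the series, on what has been measured and on what is new or still open speak of the compounds shown alone.

Compound 1 `COc1cc(-c2nccn2Cc2ccccc2)cc(OC)c1OC`: > 100000 nM (a limit of the assay)
Compound 2 `COc1cc(-c2nccn2-c2ccc(C)cc2)cc(OC)c1OC`: 20500 nM
Compound 3 `COc1cc(-c2nccn2-c2ccc(Br)cc2)cc(OC)c1OC`: 24600 nM

In a functional assay on T47D cells (Homo sapiens) for antiproliferative activity, read by MTT assay, with a stated time of 72 h (a lower number here means a stronger inhibitor, a higher number a weaker inhibitor), compound 3 gives 24600 nM, level within the scatter with compound 2 at 20500 nM. Compound 1 is known only as a limit.

Compound 4 `COc1ccc(-n2ccnc2-c2cc(OC)c(OC)c(OC)c2)cc1` carries methoxy in place of bromo on an aromatic carbon, para to a large group: methoxy in place of bromo on an aromatic carbon. The closest measured exchange is a 1.2-fold higher number from compound 2 to compound 3 (0.08 log units; within the scatter), which stays within the scatter. The larger steps, an at least 4.8-fold lower number from compound 1 to compound 2 (0.68 log units; beyond the scatter) and an at least 4.0-fold lower number from compound 1 to compound 3 (0.60 log units; beyond the scatter), replace benzyl and bear on this change only indirectly. No change beyond the scatter is therefore expected in this assay, though this rests on a single exchange. The expected step is a 1.4-fold lower number from compound 3 to compound 4 (0.14 log units; within the scatter). Compound 4 is expected at about 18000 nM, with an estimated range of 6000 nM to 55000 nM.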

Compound 4, half-maximal inhibitory concentration: 1400 nM
Beside the measured number, compound 4's estimate is 13-fold (1.11 log units) above it, and the stated range ends above it.
By their numbers in this assay, from the lowest: compound 4; then compounds 2 and 3 (each within the scatter of the next). At a limit, above all of these: compound 1.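

At this place on the ring, para to a large group, the exchange matters in this assay: bromo in place of methyl stayed within the scatter, yet methoxy gives an 18-fold lower number from compound 3 to compound 4 (1.24 log units; beyond the scatter) and a 15-fold lower number from compound 2 to compound 4 (1.17 log units; beyond the scatter). The 4-methoxyphenyl group in place of benzyl on the aromatic nitrogen gives an at least 71-fold lower number from compound 1 to compound 4 (1.85 log units; beyond the scatter). That step rests on a limit for compound 1: the limit of > 100000 nM in this assay, at which 1 of the 4 values shown sits.

The compounds shown leave open whether a hydroxyl, an ethoxy or an amine at this place would keep the lower number. They also leave open whether methoxy elsewhere on this ring would do so.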